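Chloro to nitro on compound 3: working notes

A few compounds are considered here, and "the series" means these few. Any claim that something is new, unique, unknown or untested is made for them only; others in the source may bear on it.

Measured in a functional assay on PC-3 cells (Homo sapiens) for inhibition, read by sulforhodamine B assay, with a stated time of 48 h; a lower number here means a stronger inhibitor of growth, a higher number a weaker inhibitor of growth:
- compound 1 `CCOC(=O)c1nn(-c2ccccc2)c(-c2ccc(Cl)cc2)c1CNC(C)(C)C`: 28600 nM; > 559000 nM (2 entries)
- compound 2 `CCOC(=O)c1nn(-c2ccc(Cl)cc2)c(-c2ccc(Cl)cc2)c1CNC(C)(C)C`: 196000 nM; > 519000 nM (2 entries)
- compound 3 `CC(C)(C)NCc1c(C(=O)O)nn(-c2ccccc2)c1-c1ccc(Cl)cc1`: 145000 nM

Two of the entries for compound 1 are limits of the assay and not numbers: the several entries of compound 1 in this assay, 28600 nM; > 559000 nM (2 entries). Two of the entries for compound 2 are likewise limits: the several entries of compound 2 in this assay, 196000 nM; > 519000 nM (2 entries). Compound 3 has a single numerical result in this assay, 145000 nM, and two further entries give no single number.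

Compound 4 `CC(C)(C)NCc1c(C(=O)O)nn(-c2ccccc2)c1-c1ccc([N+](=O)[O-])cc1` differs from compound 3 at one place, the 4-chlorophenyl becoming 4-nitrophenyl: nitro in place of chloro on an aromatic carbon. For the measured compounds named here, no measured pair shows this change, so the expectation starts from compound 3 at 145000 nM. No shift beyond the scatter is expected in this assay, and no direction is predicted: the expected size is a 1.0-fold lower number from compound 3 to compound 4 (0.02 log units; within the scatter). For compound 4 the estimate is 140000 nM, with an expected range of 40000 nM to 500000 nM.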

Compound 4, concentration for 50% growth inhibition: > 634000 nM
Compound 4 gave a limit, no number (the forecaster's own chance of this, stated with the estimate: 35%); middle value at least 4.5-fold (0.65 log units) away from the limit.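

In this assay compound 4 gives > 634000 nM, a limit of the assay and not a number. For the compounds shown here, replacing chloro with nitro on the aromatic carbon gives the first readable change at this position: an at least 4.3-fold higher number from compound 3 to compound 4 (0.64 log units; beyond the scatter). Going by these compounds alone, compounds 1, 2 and 3 all carry the 4-chlorophenyl, so they gave no reading of this position, and the size of the step rests on the single number of compound 3, whose two further entries give no single number.

On these data alone, whether an amine or a methoxy group at this position would give a number within the range of the assay remains open. Also open is whether the same change would move the ethyl ester of compound 1 in the same direction, given how far its entries spread: the several entries of compound 1 in this assay, 28600 nM; > 559000 nM (2 entries)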